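Aryl swap on the amine-linked chain carbon: compound 4

The source may report more compounds than this note shows. Statements on the series, on what has been measured and on what is new or still open speak of the compounds shown alone.

Compound 3 `CCCn1cc(-c2cnc(NCc3ccc4ncsc4c3)c(C(=O)NCC3COc4ccccc4O3)c2)cn1` carries a 1,3-benzothiazol-6-yl group on a saturated chain carbon bound to a nitrogen on an aromatic ring. In an assay on HEK293 cells for agonist activity at growth hormone secretagogue receptor type 1 (Rattus norvegicus), read by a luciferase reporter (a lower number here means a smaller maximal response, a higher number a larger maximal response), compound 3 reaches > 95%, which is a limit of the assay and not a number. Compound 1 `CCCn1cc(-c2cnc(NCc3ccc4sccc4c3)c(C(=O)NCC3COc4ccccc4O3)c2)cn1` gives > 95% in this assay, again a limit. Compound 2 `CCCn1cc(-c2cnc(NCc3ccc4occc4c3)c(C(=O)NCC3COc4ccccc4O3)c2)cn1` gives > 95% in this assay, also a limit. Among the compounds with values here, all three values sit at the limit of > 95% in this assay, at which 3 of the 3 values shown sit, so the steps a step that the two limits leave unreadable from compound 1 to compound 2, a step that the two limits leave unreadable from compound 1 to compound 3 and a step that the two limits leave unreadable from compound 2 to compound 3 cannot be sized; they show only that each aryl swap at this position left the response at the limit. Compound 4 `CCCn1cc(-c2cnc(NCc3ccc4c(c3)OCC4)c(C(=O)NCC3COc4ccccc4O3)c2)cn1` is not yet measured and differs from compound 3 by a group of 9 heavy atoms (8 carbon, 1 oxygen; one five-membered non-aromatic ring with 1 hetero atom, one six-membered aromatic ring of carbon only) in place of a group of 9 heavy atoms (7 carbon, 1 nitrogen, 1 sulfur; one five-membered aromatic ring with 2 hetero atoms, one six-membered aromatic ring of carbon only), on a saturated chain carbon bound to a nitrogen on an aromatic ring. The three measured swaps bear on this change, but none gives a readable size. With every measured compound at the limit, the expected step is a step that the limit leaves unreadable from compound 3 to compound 4, that is, none beyond the scatter. Compound 4 is therefore estimated at 100% in this assay, with a range from 85% to 115%, most likely reported again only as a limit.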

Compound 4, largest response reached (reported as efficacy), in percent of the reference or control that the assay uses: > 95%
Compound 4 ended at the assay's limit; the forecaster's own chance of this, stated with the estimate: 80%; the middle value lies beyond the limit too.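

In this assay compound 4 gives > 95%, a limit and not a number. Its steps from compound 1, compound 2 and compound 3 therefore cannot be read: the limit of > 95% in this assay, at which 4 of the 4 values shown sit. The compounds shown leave open whether any group on this saturated chain carbon gives a smaller maximal response.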